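Sulfamoyl for dimethylcarbamoyl on the amine of compound 2

This account rests on a few compounds, and the source may have more. Where it says the series, first, only, none or still open, it means among the compounds named here.

Compound 1 `O=S(=O)(c1cccc(F)c1)c1ccc2c(c1)CCC[C@H]2CNCCO` and compound 2 `CN(C)C(=O)NC[C@@H]1CCCc2cc(S(=O)(=O)c3cccc(F)c3)ccc21` share a core and differ only on the amine nitrogen. In an assay on isolated protein for displacement of a labelled ligand from 5-hydroxytryptamine receptor 6 (Homo sapiens) (a lower number here means a stronger inhibitor, a higher number a weaker inhibitor), compound 1 gives 0.126 nM, and compound 2 gives 2.51 nM. For the measured compounds named here, compound 2 thus stands at the higher of the two numbers measured so far, its nearest neighbour being compound 1 a 20-fold higher number from compound 1 to compound 2 (1.30 log units; beyond the scatter).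

Compound 3 `NS(=O)(=O)NC[C@@H]1CCCc2cc(S(=O)(=O)c3cccc(F)c3)ccc21` is unmeasured. It differs from compound 2 by sulfamoyl in place of dimethylcarbamoyl on an amine nitrogen. Going by the values given here, the one measured step, a 20-fold higher number from compound 1 to compound 2 (1.30 log units; beyond the scatter), concerns the exchange of 2-hydroxyethyl for dimethylcarbamoyl at the same nitrogen and does not cover the move to sulfamoyl; no measured pair shows a sulfamoylamino group. What can be said is that the dimethylcarbamoyl compound sits at the weak end of this small set, so the step to compound 3 is taken as uncertain in direction, with a modest downward lean expected, a 1.7-fold lower number from compound 2 to compound 3 (0.22 log units; within the scatter). For compound 3 in this assay the estimate is 1.5 nM, with the range 0.3 nM to 8 nM expected to hold most repeat measurements.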

Compound 3, inhibition constant: 0.126 nM
Estimate against measurement, compound 3: 12-fold (1.08 log units) above, outside the stated range (below it).
By their numbers in this assay, from the lowest: compounds 1 and 3 (each within the scatter of the next); then compound 2.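

The amine nitrogen does not simply lose affinity when 2-hydroxyethyl is replaced: in this assay, the change to sulfamoyl gives a 20-fold lower number from compound 2 to compound 3 (1.30 log units; beyond the scatter), so the earlier loss belongs to dimethylcarbamoyl and not to every replacement at this nitrogen. With no change at the digits printed from compound 1 to compound 3 (within the scatter), sulfamoyl and 2-hydroxyethyl cannot be told apart here, which leaves compound 2 as the weakest of the three and shows that this position accepts two quite different groups without a measurable difference. Sulfamoyl brings one hydrogen-bond donor and dimethylcarbamoyl none, but no measurement bears on why the two groups differ so widely.

Still open, going by these compounds, is whether the gap follows the sulfur, the free amino hydrogens or the two methyl groups of dimethylcarbamoyl: on the same amine nitrogen, an unsubstituted carbamoyl, a dimethylsulfamoyl or a methylsulfonyl group would begin to separate these. Also open, on these data alone, is whether a longer chain bearing a terminal sulfamoyl or hydroxyl group would stay with compound 1 and compound 3 or fall toward compound 2.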